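Hydroxypropyl in place of dioxolanylethyl in a weak series

The source may report more compounds than this note shows. Statements on the series, on what has been measured and on what is new or still open speak of the compounds shown alone.

Working notes on three measured compounds and one awaiting measurement. In an assay on 32D cells for inhibition of interleukin-15 (Mus musculus), read by resazurin assay, with stated times of 30 min and 2.5 days, in the presence of a further agent that is not named here (a lower number here means a stronger inhibitor, a higher number a weaker inhibitor), compound 1 `Cn1nc(Cc2nnc(SCC(=O)Nc3ccc(Cl)cc3Cl)n2CCC=O)c2ccccc2c1=O` gives 6000 nM. Compound 2 `CN(C)CCCn1c(Cc2nn(C)c(=O)c3ccccc23)nnc1SCCCCCCCC(=O)Nc1ccc(Cl)cc1Cl` gives 3700 nM in this assay; the values of compound 1 and compound 2 lie within the usual scatter of each other, so no order between them is claimed. Compound 3 `Cn1c(Cc2nn(CCC3OCCO3)c(=O)c3ccccc23)nnc1SCC(=O)Nc1ccc(Cl)cc1Cl` is recorded in this assay only as a limit of the assay, > 30000 nM. Compound 3 therefore stands at the limit of > 30000 nM in this assay, at which 1 of the 3 values shown sits, the one entry among the three that is a limit rather than a number.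

Compound 4 `Cn1c(Cc2nn(CCCO)c(=O)c3ccccc23)nnc1SCC(=O)Nc1ccc(Cl)cc1Cl` differs from compound 3 in one place: hydroxymethyl in place of 1,3-dioxolan-2-yl on a saturated chain carbon, two bonds along the chain from an aromatic nitrogen. Among the compounds with values here, no step between two measured compounds isolates this change; compound 1 and compound 2 each differ from compound 3 in more than one place, so they show only their own values. Since compound 3 is known only as a limit, the expected step is itself open at one end; a small move toward stronger inhibition, not clearly beyond the scatter, is expected from compound 3 to compound 4 in this assay, an at least 1.5-fold lower number from compound 3 to compound 4 (0.17 log units; that floor lies within the scatter). For compound 4 the estimate in this assay is 20000 nM, with an expected range from 6000 nM to 60000 nM, and a fair chance that the assay again returns only a limit.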

Compound 4, half-maximal inhibitory concentration: > 30000 nM
Compound 4: a limit, no number (the forecaster's own chance of this, stated with the estimate: 40%); middle value at least 1.5-fold (0.17 log units) away from the limit.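

Compound 3 and compound 4 both stand at a limit of this assay, so no step between them can be read: the limit of > 30000 nM in this assay, at which 2 of the 4 values shown sit.

The compounds shown leave open whether hydroxymethyl in place of 1,3-dioxolan-2-yl, on a saturated chain carbon, two bonds along the chain from an aromatic nitrogen, shifts inhibition in either direction.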